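Aryl substituent removal on a pyrrolidine alpha-glucosidase inhibitor

The compounds below may be only part of what the source reports. "The series", "measured", "known", "first", "only" and "open" are said of these compounds alone.

Compound 1 `OC[C@]1(c2ccc(F)cc2)NC[C@H](O)[C@H]1O` gives 101000 nM in an assay on isolated protein for inhibition of lysosomal alpha-glucosidase (Rattus norvegicus), read by colorimetric assay; on this read-out lower numbers stand for stronger inhibition and higher numbers for weaker inhibition. Compound 2 `Cc1ccc([C@@]2(CO)NC[C@H](O)[C@H]2O)cc1` gives 17000 nM. Compound 3 `COc1cccc([C@@]2(CO)NC[C@H](O)[C@H]2O)c1` gives 108000 nM.

Compound 3 stands highest of the three numbers, within the scatter of compound 1 and well apart from compound 2. Compound 4 `OC[C@]1(c2ccccc2)NC[C@H](O)[C@H]1O` differs from compound 3 by hydrogen in place of methoxy on an aromatic carbon. Among the measured compounds shown here, the only measured step, a 5.9-fold lower number from compound 1 to compound 2 (0.77 log units; beyond the scatter), exchanges one group for another on the aromatic carbon rather than removing one, so it bears on this change only loosely; it shows that a small change on that ring can move the number modestly. For the measured compounds named here, with no closer precedent, the number for compound 4 is expected to lie between those of compound 3 and compound 2, with a 1.8-fold lower number from compound 3 to compound 4 (0.26 log units; within the scatter) as the estimated step. Compound 4 is therefore estimated at 60000 nM, between 15000 nM and 200000 nM.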

Compound 4, half-maximal inhibitory concentration: 190 nM
Beside the measured number, compound 4's estimate is 320-fold (2.50 log units) above it, and the stated range ends above it.
By their numbers in this assay, from the lowest: compound 4; then compound 2; then compounds 1 and 3 (each within the scatter of the next).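

Replacing any of the three groups with hydrogen lowers the number sharply: loss of methoxy gives a 570-fold lower number from compound 3 to compound 4 (2.75 log units; beyond the scatter) and loss of fluoro gives a 530-fold lower number from compound 1 to compound 4 (2.73 log units; beyond the scatter) while loss of methyl gives an 89-fold lower number from compound 2 to compound 4 (1.95 log units; beyond the scatter) in each case. The earlier compounds shown here showed only how substituted rings differ from one another, whereas these steps show that all three substituted compounds lie far above the unsubstituted compound 4. Nothing measured here explains the size of these steps.

From the compounds shown here alone, whether any group on this ring can match hydrogen remains open. A hydroxyl, an amine or a carboxylic acid on that aromatic carbon would test this.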